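Methyl for bromo on the para carbon: compound 4 expected

This account rests on a few compounds, and the source may have more. Where it says the series, first, only, none or still open, it means among the compounds named here.

Measured compounds and their values:
Compound 1 `Oc1ccccc1/C=N/c1nnc(SCc2nnc(-c3ccccc3Cl)o2)s1` gives 31800 nM in a functional assay on SMMC-7721 cells (Homo sapiens) for inhibition, read by CCK-8 assay; on this read-out lower numbers stand for stronger inhibition and higher numbers for weaker inhibition.
Compound 2 `Oc1ccccc1/C=N/c1nnc(SCc2nnc(-c3ccccc3Br)o2)s1` gives 6780 nM in this assay.
Compound 3 `Oc1ccccc1/C=N/c1nnc(SCc2nnc(-c3ccc(Br)cc3)o2)s1` gives 18000 nM in this assay.

Compound 3 sits second highest of the three numbers in this assay. Its nearest neighbour is compound 1, with a 1.8-fold lower number from compound 1 to compound 3 (0.25 log units; within the scatter), a step within the scatter; the furthest is compound 2, with a 2.7-fold higher number from compound 2 to compound 3 (0.42 log units; beyond the scatter), a modest step beyond the scatter.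

Compound 4 `Cc1ccc(-c2nnc(CSc3nnc(/N=C/c4ccccc4O)s3)o2)cc1` is the unmeasured partner. It differs from compound 3 by methyl in place of bromo on an aromatic carbon. Among the compounds with values here, none of the measured steps swaps bromo for methyl. Within the data shown here, the closest precedent is the halogen swap a 4.7-fold lower number from compound 1 to compound 2 (0.67 log units; beyond the scatter), which changed the number modestly, but that step sits on a different carbon and exchanges one halogen for another. The positional step a 2.7-fold higher number from compound 2 to compound 3 (0.42 log units; beyond the scatter) shows that the same halogen on the para carbon gives a somewhat higher number than on the ortho carbon, which says nothing about a methyl there.

Among the measured compounds shown here, with no direct precedent, compound 4 is expected to stay close to compound 3, with a 1.1-fold higher number from compound 3 to compound 4 (0.05 log units; within the scatter) judged to lie within the scatter. Compound 4 is therefore estimated at 20000 nM, with a range from 7000 nM to 55000 nM.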

Compound 4, half-maximal inhibitory concentration: 37100 nM
Compound 4: middle estimate off by 1.9-fold (0.27 log units), on the low side; the range from low to high includes it.
By their numbers in this assay, from the lowest: compound 2; then compounds 3, 1 and 4 (each within the scatter of the next, the first and the last beyond it).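

In this assay, within the data shown here, this is the first exchange of a halogen for a carbon group on the aromatic carbon para to a large group, and it is not a neutral one: a 2.1-fold higher number from compound 3 to compound 4 (0.31 log units; beyond the scatter), a modest rise beyond the scatter, shows that 4-methylphenyl does not hold the number reached with 4-bromophenyl. The methyl compound also stands clearly apart from the 2-bromophenyl compound, a 5.5-fold higher number from compound 2 to compound 4 (0.74 log units; beyond the scatter), while it cannot be told apart from the 2-chlorophenyl compound, a 1.2-fold higher number from compound 1 to compound 4 (0.07 log units; within the scatter), so compound 2 keeps the lowest number of the four and methyl brings no gain over either bromo compound. Nothing available explains why the number moves with this exchange.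

The compounds shown leave open whether a methoxy group, an amine or a carboxylic acid on this same aromatic carbon would lower the number or raise it further. Among these compounds, they also leave open how a methyl would behave on the carbon that carries the bromo in compound 2, the one place where the number has so far come down most.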